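A few compounds are considered here, and "the series" means these few. Any claim that something is new, unique, unknown or untested is made for them only; others in the source may bear on it.

Of the compounds shown here, three sharing one core have been measured in an in vitro functional assay on HEK285-7 cells for antagonist activity at prostaglandin D2 receptor 2 (Homo sapiens), read by BRET and beta-arrestin recruitment; a lower number here means a stronger inhibitor, a higher number a weaker inhibitor. Compound 1 `O=C(O)Cc1sc(C(c2ccc(F)cc2)c2ccc(F)cc2)nc1-c1cccc(F)c1` gives 18 nM. Compound 2 `N#Cc1cc(-c2nc(C(c3ccc(F)cc3)c3ccc(F)cc3)sc2CC(=O)O)ccc1F` gives 520 nM, and compound 3 `O=C(O)Cc1sc(C(c2ccc(F)cc2)c2ccc(F)cc2)nc1-c1ccncc1` gives 40 nM. Among these three numbers compound 3 stands second highest: the step of a 2.2-fold higher number from compound 1 to compound 3 (0.35 log units; beyond the scatter) was modest, while the step of a 13-fold lower number from compound 2 to compound 3 (1.11 log units; beyond the scatter) was large. The step of a 29-fold higher number from compound 1 to compound 2 (1.46 log units; beyond the scatter) shows how strongly an exchange of this aromatic ring can move the number in this assay.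

Compound 4 `Cc1cc(-c2nc(C(c3ccc(F)cc3)c3ccc(F)cc3)sc2CC(=O)O)ccn1` differs from compound 3 by methyl in place of hydrogen on an aromatic carbon. Going by the values given here, none of the measured steps alters this ring in the same way; all three swap the whole ring for another. Adding a single carbon next to the ring nitrogen is a far smaller change than any of those swaps, and the nearest comparison, the step of a 2.2-fold higher number from compound 1 to compound 3 (0.35 log units; beyond the scatter), was itself only modest. A step in this assay of no more than the usual scatter is therefore expected, and its direction cannot be told from the three measured compounds. Compound 4 is estimated at 35 nM, with a likely range from 14 nM to 90 nM, which corresponds to an expected step of a 1.1-fold lower number from compound 3 to compound 4 (0.06 log units; within the scatter).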

Compound 4, half-maximal inhibitory concentration: 53 nM
Compound 4: middle estimate off by 1.5-fold (0.18 log units), on the low side; the measured number falls inside the stated range.
By their numbers in this assay, from the lowest: compound 1; then compounds 3 and 4 (each within the scatter of the next); then compound 2.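

In this assay, methyl in place of hydrogen on the aromatic carbon next to the ring nitrogen turns pyridin-4-yl into 2-methylpyridin-4-yl, and the step (a 1.3-fold higher number from compound 3 to compound 4 (0.12 log units; within the scatter)) stays within the scatter, so compound 3 and compound 4 cannot be told apart. The earlier steps shown here each exchanged a whole ring, whereas this one shows that a small addition at this position of the pyridine ring can be made without a measurable change, and the wider picture holds: the 2-methylpyridin-4-yl ring stays well ahead of the 3-cyano-4-fluorophenyl ring (a 9.8-fold lower number from compound 2 to compound 4 (0.99 log units; beyond the scatter)) but behind the 3-fluorophenyl ring (a 2.9-fold higher number from compound 1 to compound 4 (0.47 log units; beyond the scatter)). Nothing measured here explains why the methyl makes so little difference.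

Going by these compounds alone, one methyl shows only that this single carbon group is accepted, so it remains open whether an ethyl, a methoxy or an amine on the same carbon would leave the number just as unmoved. Going by these compounds, it also remains open whether a methyl placed elsewhere on this ring, or a chlorine on the same carbon, would behave as this methyl does.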